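Replacing an imidazole with an ethylurea on the shared core

The compounds below may be only part of what the source reports. "The series", "measured", "known", "first", "only" and "open" are said of these compounds alone.

Compound 3 `O=C1O[C@@H](Cn2ccnc2)CN1c1ccc(-n2cc(-c3ccccn3)cn2)c(F)c1`: 1.73
Compound 1 `CCN1CCN(C[C@H]2CN(c3ccc(-n4cc(-c5ccccn5)cn4)c(F)c3)C(=O)O2)CC1`: 2.19
Compound 2 `O=C(OC[C@H]1CN(c2ccc(-n3cc(-c4ccccn4)cn3)c(F)c2)C(=O)O1)c1ccccc1`: 4.21

In a physicochemical assay for lipophilicity, read by HPLC, measured as octanol-water partition (a lower number here means a more polar compound, a higher number a more lipophilic compound), compound 3 gives the lowest of the three numbers. Compound 1 stands above it by a number 0.46 log units lower from compound 1 to compound 3 (beyond the scatter), and compound 2 further still by a number 2.48 log units lower from compound 2 to compound 3 (beyond the scatter). Compound 4 `CCNC(=O)NC[C@H]1CN(c2ccc(-n3cc(-c4ccccn4)cn3)c(F)c2)C(=O)O1` differs from compound 3 by (ethylcarbamoyl)amino in place of 1H-imidazol-1-yl on a saturated chain carbon bound to a saturated ring carbon. The two measured steps at this position are large or modest and both replace a basic or ester group with a ring; none replaces a ring with an open urea chain, so they set a scale but no direction. The group entering counts one more heavy atom and adds donors, and compound 4 is expected to stay close to compound 3, with a number 0.13 log units lower from compound 3 to compound 4 (within the scatter) inside the scatter. Compound 4 is therefore estimated at 1.6, within 1.1 to 2.1.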

Compound 4, partition coefficient: 2.45
Estimate against measurement, compound 4: 0.85 log units below, and the stated range ends below it.
By their numbers in this assay, from the lowest: compound 3; then compounds 1 and 4 (each within the scatter of the next); then compound 2.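

Replacing 1H-imidazol-1-yl with (ethylcarbamoyl)amino on a saturated chain carbon bound to a saturated ring carbon gives, in this assay, a number 0.72 log units higher from compound 3 to compound 4 (beyond the scatter), although the entering group has no ring and adds hydrogen-bond donors. Against the other groups it gives a number 0.26 log units higher from compound 1 to compound 4 (within the scatter), leaving it not separated from 4-ethylpiperazin-1-yl, and a number 1.76 log units lower from compound 2 to compound 4 (beyond the scatter), so benzoyloxy remains clearly apart from all three other groups. Nothing available gives a cause for these differences.

Going by these compounds, it remains open whether a longer chain on the urea would shift the number further. On these data alone, a primary amine or a carboxylic acid at this place also remains untested against these groups.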